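The source may hold more compounds than are shown below. What is called first, only, known or untested is meant among the compounds shown, and "the series" means these compounds.

Measured compounds in a functional assay on the whole organism for inhibition, with Nicotiana tabacum as the target; on this read-out higher numbers stand for weaker inhibition and lower numbers for stronger inhibition:
compound 1, `CCCc1ccc(Nc2[nH]c(C)nc3nccc2-3)cc1`, 105000000 nM
compound 2, `Cc1nc(NC2CCCC2)c2cc[nH]c2n1`, 72400000 nM
compound 3, `Cc1nc(NC2CCCCC2)c2cc[nH]c2n1`, 891000000 nM

Compound 2 carries the lowest number of the three in this assay. Against compound 1 the gap is within the scatter, so no order between these two can be read. Against compound 3 the gap lies beyond the scatter, and compound 3 stands weaker.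

Compound 4, `Cc1nc(NC(C)(C)O)c2cc[nH]c2n1`, is not yet measured. Its change from compound 2 is 1-hydroxy-1-methylethyl in place of cyclopentyl on a nitrogen on an aromatic ring. Going by the values given here, no measured step of this kind exists, so the size and direction are open. The expectation is a step from compound 2 to compound 4 of a 2.1-fold higher number from compound 2 to compound 4 (0.32 log units; beyond the scatter), toward weaker inhibition, with wide uncertainty. Compound 4 is estimated at 150000000 nM, in a range from 30000000 nM to 1000000000 nM.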

Compound 4, half-maximal inhibitory concentration: 166000000 nM
Compound 4: middle estimate off by 1.1-fold (0.04 log units), on the low side; low and high end bracket the measured number.
By their numbers in this assay, from the lowest: compounds 2, 1 and 4 (each within the scatter of the next, the first and the last beyond it); then compound 3.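

Going by these compounds alone, this is the first measured step on this nitrogen on an aromatic ring: in this assay, 1-hydroxy-1-methylethyl in place of cyclopentyl gives a 2.3-fold higher number from compound 2 to compound 4 (0.36 log units; beyond the scatter), a modest move toward weaker inhibition. The carbon-only ring can therefore be lost and a hydrogen-bond donor and acceptor brought in at only a modest cost in this read-out. Nothing available explains the step. Still open, on these data alone, is whether the lost ring or the entering hydroxyl carries the step. A tert-butyl group in the same place would separate the two.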